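Swapping the urea aryl cap on a shared quinazoline-type core

A few compounds are considered here, and "the series" means these few. Any claim that something is new, unique, unknown or untested is made for them only; others in the source may bear on it.

Of the compounds shown here, two carry a measured number so far. Compound 1, `CN1CCC(COc2ccc3c(Nc4ccc(NC(=O)Nc5cccc(F)c5)c(Cl)c4)ncnc3c2)CC1`, gives 132 nM in a functional assay on HUVEC cells (Homo sapiens) for antiproliferative activity, read by sulforhodamine B assay, with a stated time of 48 h; a lower number here means a stronger inhibitor, a higher number a weaker inhibitor. Compound 2, `Cc1ccc(NC(=O)Nc2ccc(Nc3ncnc4cc(OCC5CCN(C)CC5)ccc34)cc2)cc1Br`, gives 196 nM in this assay; this is the larger of the two numbers, but the gap to compound 1 lies within the scatter of repeated measurements, so the two cannot be told apart on these values. Among the compounds with values here, the two compounds differ in more than one place, so no single step connects them.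

Compound 3, `CN1CCC(COc2ccc3c(Nc4ccc(NC(=O)Nc5ccc(Br)cc5F)cc4)ncnc3c2)CC1`, has not yet been measured in this assay. It differs from compound 2 at one site: 4-bromo-2-fluorophenyl in place of 3-bromo-4-methylphenyl on an amide-type nitrogen. The count of heavy atoms, donors and acceptors does not change; only the pattern of substituents on the cap moves.

Within the data shown here, with no measured step of this kind to lean on, no change beyond the scatter is expected in this assay. Compound 3 is expected to give 170 nM, within 70 nM to 450 nM. The estimated step of a 1.2-fold lower number from compound 2 to compound 3 (0.06 log units; within the scatter) is expected to stay inside the usual scatter.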

Compound 3, half-maximal inhibitory concentration: 233 nM
The estimate for compound 3 lay 1.4-fold (0.14 log units) below the measured number; the range from low to high includes it.
By their numbers in this assay, from the lowest: compounds 1, 2 and 3 (each within the scatter of the next).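

The swap of 3-bromo-4-methylphenyl for 4-bromo-2-fluorophenyl on an amide-type nitrogen gives the series its first single-site step, a 1.2-fold higher number from compound 2 to compound 3 (0.08 log units; within the scatter) in this assay, so on these numbers the two caps cannot be told apart. Both caps have the same count of heavy atoms, and both keep a bromine on one six-membered aromatic ring, yet they differ in the methyl carried by one and the fluorine carried by the other, as well as in the placing of the bromine; that whole difference at this position leaves the read-out inside the scatter for this one pair. Nothing measured alongside these numbers speaks to the reason for this result.

The compounds shown carry only halogen and methyl substituents on the aryl cap, so it remains open whether a cap bearing a carboxylic acid, a dimethylamino group or a longer alkyl chain would also stay inside the scatter. Within the data shown here, it also remains open whether this same swap would read the same way on the chlorine-bearing aniline ring of compound 1, since that compound is linked to the others by no single step.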